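A few compounds are considered here, and "the series" means these few. Any claim that something is new, unique, unknown or untested is made for them only; others in the source may bear on it.

Working notes on the series. In a functional assay on THP-1 cells (Homo sapiens) for inhibition, read by sulforhodamine B assay, with a stated time of 48 h, tested at 50 uM (a higher number here means more inhibition of growth at the concentration tested, a lower number less inhibition of growth), compound 1 `COc1cc(/C=C/C(=O)/C=C/c2cccc3ccccc23)ccc1OCc1cn(CCOc2cc(=O)oc3ccccc23)nn1` gives 89% and compound 2 `COc1ccc(/C=C/C(=O)/C=C/c2ccc(OCc3cn(CCCCOc4cc(=O)oc5ccccc45)nn3)c(OC)c2)cc1OC` gives 59% while compound 3 `COc1cc(/C=C/C(=O)/C=C/c2cccc3ccccc23)ccc1OCc1cn(CCCCCOc2cc(=O)oc3ccccc23)nn1` gives 44% at the single concentration tested. Compound 2 is thus second highest of the three, with compound 1 above it and compound 3 below it, both gaps beyond the scatter.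

Compound 4 `COc1cccc(/C=C/C(=O)/C=C/c2ccc(OCc3cn(CCCCOc4cc(=O)oc5ccccc45)nn3)c(OC)c2)c1` differs from compound 2 in one place, with hydrogen in place of methoxy on an aromatic carbon, so that 3,4-dimethoxyphenyl becomes 3-methoxyphenyl (hydrogen in place of methoxy on an aromatic carbon). For the measured compounds named here, no measured pair isolates a single change, so the data offer no size or direction for this one. In this assay the expectation is therefore no step beyond the scatter, with compound 2 at 59% as the anchor. The expected step is a number 2 percentage points lower from compound 2 to compound 4 (within the scatter) on this reading. For compound 4 the estimate is 57% with an expected range of 40% to 74% once measured.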

Compound 4, percent growth inhibition at one concentration: 47%
Estimate against measurement, compound 4: 10 percentage points above; the range from low to high includes it.
By their numbers in this assay, from the lowest: compounds 3 and 4 (each within the scatter of the next); then compound 2; then compound 1.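

In this assay, for the compounds shown here, hydrogen in place of methoxy on this aromatic carbon, taking 3,4-dimethoxyphenyl to 3-methoxyphenyl, gives a number 12 percentage points lower from compound 2 to compound 4 (beyond the scatter), the only single-place change whose size and direction can be read. This position, ortho to a methoxy group and para to a large group, is therefore not neutral to the change: in this one pair, methoxy goes with more growth inhibition at the single concentration tested than hydrogen. Nothing available bears on what lies behind the step.

Open, as far as these compounds go, is whether a hydroxyl, an ethoxy group or an amine on this carbon would read closer to methoxy or to hydrogen. Also open, from the compounds shown here alone, is whether the step holds with a shorter or longer chain, as compounds 1 and 3 each differ from compound 2 in more than one place.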